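This account rests on a few compounds, and the source may have more. Where it says the series, first, only, none or still open, it means among the compounds named here.

Three members of the series have numbers in an assay on CHO cells for displacement of a labelled ligand from 5-hydroxytryptamine receptor 1B (Homo sapiens); on this read-out higher numbers stand for weaker inhibition and lower numbers for stronger inhibition. Compound 3 `CN(Cc1ccco1)C1CCN(CCCc2c[nH]c3ccc(-n4cnnc4)cc23)CC1` gives 89 nM, the lowest of the three. Compound 2 `CN(Cc1ccc(S(C)(=O)=O)cc1)C1CCN(CCCc2c[nH]c3ccc(-n4cnnc4)cc23)CC1` gives 140 nM, and compound 1 `O[C@H]1Cc2ccccc2C1NC1CCN(CCCc2c[nH]c3ccc(-n4cnnc4)cc23)CC1` gives 300 nM. The step of a 1.6-fold lower number from compound 2 to compound 3 (0.20 log units; within the scatter) exchanges furan-2-yl for 4-(methylsulfonyl)phenyl on a saturated chain carbon bound to an amine nitrogen; the step of a 3.4-fold lower number from compound 1 to compound 3 (0.53 log units; beyond the scatter) replaces the whole amine substituent on the saturated ring carbon. Compound 4 `c1cncc(CNC2CCN(CCCc3c[nH]c4ccc(-n5cnnc5)cc34)CC2)c1` is not yet measured; it carries ((pyridin-3-yl)methyl)amino in place of ((furan-2-yl)methyl)(methyl)amino on a saturated ring carbon. Both steps bear on it: the arene exchange stayed within the scatter, the larger amine replacement was modest. A step of a 1.3-fold higher number from compound 3 to compound 4 (0.13 log units; within the scatter) is therefore expected, small and likely within the scatter. For compound 4 the estimate in this assay is 120 nM, with a range of 40 nM to 350 nM.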

Compound 4, half-maximal inhibitory concentration: 140 nM
For compound 4 the middle estimate is 1.2-fold (0.07 log units) below the measured one; the range from low to high includes it.
By their numbers in this assay, from the lowest: compounds 3, 2 and 4 (each within the scatter of the next); then compound 1.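

In this assay, a 1.6-fold higher number from compound 3 to compound 4 (0.20 log units; within the scatter) exchanges the aromatic ring and loses the methyl on the amine nitrogen together, yet the two amine substituents on this saturated ring carbon cannot be told apart. With a 2.1-fold lower number from compound 1 to compound 4 (0.33 log units; beyond the scatter), the amine hydrogen stays and only the group on the amine nitrogen changes, so a separation from compound 1 does not require the methyl. No evidence at hand accounts for either step.

On these data alone, the separate contributions of the methyl and the aromatic ring remain open. So does the outcome with a cyclohexylmethyl group on the amine nitrogen.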